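Swapping the aryl group on the phenoxy side chain

The compounds below may be only part of what the source reports. "The series", "measured", "known", "first", "only" and "open" are said of these compounds alone.

Measured compounds:
- Compound 1 `COc1cc(CC(C)C(=O)N2CCN(c3ccc(C(F)(F)F)cc3[C@@H](N)CC(C)C)CC2)ccc1Cl`: 230 nM
- Compound 2 `COc1ccc(OCC(=O)N2CCN(c3ccc(C(F)(F)F)cc3[C@@H](N)CC(C)C)CC2)cc1`: 3800 nM
- Compound 3 `Cc1ccc(OCC(=O)N2CCN(c3ccc(C(F)(F)F)cc3[C@@H](N)CC(C)C)CC2)cc1`: 4400 nM

In an assay on HEK293 cells for displacement of a labelled ligand from Melanocortin receptor 4 (Homo sapiens) (a lower number here means a stronger inhibitor, a higher number a weaker inhibitor), compound 3 gives the highest number of the three, far from compound 1 but close to compound 2. Compound 4 `CC(C)C[C@H](N)c1cc(C(F)(F)F)ccc1N1CCN(C(=O)COc2cccc(Cl)c2Cl)CC1` is reached from compound 3 by one change: 2,3-dichlorophenyl in place of 4-methylphenyl on an oxygen on a saturated carbon. For the measured compounds named here, no measured step touches that exact exchange. The nearest guide is a 1.2-fold higher number from compound 2 to compound 3 (0.06 log units; within the scatter), a change on the same ring that made no difference beyond the scatter, whereas a 19-fold higher number from compound 1 to compound 3 (1.28 log units; beyond the scatter) shows how much rebuilding the whole side chain can matter. With only the ring substituents altered here, a step of a 1.5-fold lower number from compound 3 to compound 4 (0.17 log units; within the scatter) is expected, within the scatter. Compound 4 is therefore estimated at 3000 nM, likely between 800 nM and 12000 nM.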

Compound 4, inhibition constant: 2500 nM
Compound 4: middle estimate off by 1.2-fold (0.08 log units), on the high side, and the stated range covers the measured number.
By their numbers in this assay, from the lowest: compound 1; then compounds 4, 2 and 3 (each within the scatter of the next).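

Replacing 4-methylphenyl with 2,3-dichlorophenyl on this oxygen stays within the scatter (a 1.8-fold lower number from compound 3 to compound 4 (0.25 log units; within the scatter)), as does replacing 4-methoxyphenyl (a 1.5-fold lower number from compound 2 to compound 4 (0.18 log units; within the scatter)), so all three phenoxy compounds now read alike. The large gap to the side chain of compound 1 remains (an 11-fold higher number from compound 1 to compound 4 (1.04 log units; beyond the scatter)), so this ring change does not close it. No evidence here explains these results. Still open, from the compounds shown here alone, is whether an amine or a carboxylic acid on this ring, or a longer chain in place of the (2,3-dichlorophenoxy)methyl group, would shift the number beyond the scatter.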